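An anilino group replaces isopropoxy on a shared core

The source may report more compounds than this note shows. Statements on the series, on what has been measured and on what is new or still open speak of the compounds shown alone.

Compound 1 `CO[C@H]1[C@@H]2C(=O)/C(C)=C\C3=C[C@H](C)C[C@@]34O[C@]2(CC1(C)C)[C@@H](C)C4=O`: 26000 nM
Compound 2 `C/C1=C/C2=C[C@H](C)C[C@@]23O[C@]2(CC(C)(C)[C@@H](OC(C)C)[C@@H]2C1=O)[C@@H](C)C3=O`: 26000 nM

Both values come from an ADME assay on HEK293 cells (Homo sapiens) for cytotoxicity, read by CellTiter-Glo, with a stated time of 72 h; on this read-out higher numbers stand for an effect only at larger amounts of compound and lower numbers for an effect already at smaller amounts. Among the measured compounds shown here, on these numbers, compound 1 is the only measured neighbour and stands level with compound 2 at 26000 nM.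

The next compound is compound 3 `C/C1=C/C2=C[C@H](C)C[C@@]23O[C@]2(CC(C)(C)[C@@H](Nc4ccccc4)[C@@H]2C1=O)[C@@H](C)C3=O`, which differs from compound 2 as follows: anilino in place of isopropoxy on a saturated ring carbon. For the measured compounds named here, only one measured step bears on this change: no change at the digits printed from compound 1 to compound 2 (within the scatter). That step altered only the group on an oxygen, while compound 3 brings in a six-membered aromatic ring of carbon only, so it is a weak guide. No step beyond the scatter is therefore expected in this assay, and any drift is expected towards lower numbers. The estimated step is a 1.3-fold lower number from compound 2 to compound 3 (0.11 log units; within the scatter). For compound 3 the expected value is 20000 nM, with an estimated range of 7000 nM to 50000 nM.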

Compound 3, half-maximal effective concentration: 26000 nM
Compound 3: middle estimate off by 1.3-fold (0.11 log units), on the low side, within the range that was stated.
By their numbers in this assay, from the lowest: compounds 1, 2 and 3 (each within the scatter of the next).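

Putting an aromatic ring on this saturated ring carbon, and a hydrogen-bond donor with it, gives no change at the digits printed from compound 2 to compound 3 (within the scatter) in this assay. Measured against the smaller methoxy group, the same position gives no change at the digits printed from compound 1 to compound 3 (within the scatter), so at this carbon the read-out has now held through a change of the atom attached to the ring and not only through a change of the group on the oxygen. No measurement shown here accounts for this lack of movement. On these data alone, whether a carboxylic acid or a piperazine at this carbon would shift the number beyond the scatter remains open. So does the question of whether an anilino group carrying a chlorine on its ring would behave like the plain anilino group of compound 3.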